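Notes on the Saturated Ring Carbon Series

The source may hold more compounds than are shown below. What is called first, only, known or untested is meant among the compounds shown, and "the series" means these compounds.

Of the compounds shown here, three have been measured in an assay on HeLa cells for displacement of a labelled ligand from adenosine receptor A3 (Homo sapiens), read by radioligand binding, with a stated time of 180 min, tested at 1 uM; on this read-out lower numbers stand for less inhibition and higher numbers for more inhibition at the one concentration tested (going by the name of the read-out). Compound 1 `CCOC(=O)C1=C(C(F)(F)F)NC(=O)NC1c1ccsc1` gives 3%. Compound 2 `CC1=C(C(=O)OCC(F)(F)F)C(c2ccsc2)NC(=O)N1` gives 1%, and compound 3 `CC1=C(C(=O)OCC(F)(F)F)C(c2ccoc2)NC(=O)N1` gives 1%. All three numbers lie within the scatter of one another, so no order among them is claimed.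

Among the compounds with values here, the one measured step in this assay is no change at the digits printed from compound 2 to compound 3 (within the scatter); the change behind it is furan-3-yl in place of thiophen-3-yl on a saturated ring carbon. The cores of compound 1 and compound 2 hold the same atoms joined differently; that difference is not broken down here.

Compound 4 `CCOC(=O)C1=C(C(F)(F)F)NC(=O)NC1c1ccoc1` is not yet measured. It arises from compound 1 by furan-3-yl in place of thiophen-3-yl on a saturated ring carbon. The surroundings differ: in compound 1 the saturated ring carbon is next to the ring atom that bears an ethoxycarbonyl group and two ring bonds from the ring atom that bears a trifluoromethyl group, whereas in compound 2 it is next to the ring atom that bears a group of 8 heavy atoms and two ring bonds from the ring atom that bears a methyl group. It is thus the same kind of change, not the same. A step of about no change at the digits printed from compound 1 to compound 4 (within the scatter) is expected in this assay, resting on the step of no change at the digits printed from compound 2 to compound 3 (within the scatter) and on compound 1 at 3%. Compound 4 is estimated at 3%, ranging from -7% to 13%.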

Compound 4, a percentage reported as inhibition, at one concentration (the size of the read-out at that concentration, not a potency): 1%
Compound 4: middle estimate off by 2 percentage points, on the high side; measured number inside the range.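

In this assay, furan-3-yl in place of thiophen-3-yl on the saturated ring carbon of the core of compound 1 gives a number 2 percentage points lower from compound 1 to compound 4 (within the scatter). Set beside the earlier step, the change reads alike on the two cores: the same change on two cores in this assay, no change at the digits printed (within the scatter) from compound 2 to compound 3 and a number 2 percentage points lower (within the scatter) from compound 1 to compound 4, 2 percentage points apart, within the scatter of two such steps This shows only that the change, carried between these two cores, stays within the scatter here; with all four compounds within the scatter of one another at the one concentration tested, it does not show that the change would carry over in the same way where the read-out gives larger numbers, or to any third core.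

Every compound shown bears thiophen-3-yl or furan-3-yl on the saturated ring carbon, so a phenyl or pyridinyl group at that place remains open. Also open, going by these compounds, is how an amine, a carboxylic acid or a longer chain in place of the trifluoromethyl group on the core of compound 1 would read in this assay.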